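A few compounds are considered here, and "the series" means these few. Any claim that something is new, unique, unknown or untested is made for them only; others in the source may bear on it.

Two compounds in the series have numbers. In an in vitro assay on 293-EBNA cells for binding affinity to corticotropin-releasing factor receptor 1 (Homo sapiens) (on this read-out lower numbers stand for stronger inhibition and higher numbers for weaker inhibition), compound 1 `CCC(COC)N(C)c1nc(C)nc2c1nnn2-c1ccc(C(C)C)cc1Br` gives 11.2 nM, the highest of the two; compound 2 `CCCC(CCC)Nc1nc(C)nc2c1nnn2-c1ccc(Br)cc1Br` gives 0.8 nM in this assay, a lower number, and the two structures differ in more than one place, so the pair says nothing about any single change. Compound 3 `CCCC(CN(C)C)Nc1nc(C)nc2c1nnn2-c1ccc(C(C)C)cc1Br` is the unmeasured step from compound 1: a group of 9 heavy atoms (7 carbon, 2 nitrogen; no ring) in place of a group of 8 heavy atoms (6 carbon, 1 nitrogen, 1 oxygen; no ring), on an aromatic carbon. Among the measured compounds shown here, no measured step bears on this change, and the expected step of a 1.9-fold lower number from compound 1 to compound 3 (0.27 log units; within the scatter) is a small lowering of the number, within the usual scatter. Compound 3 is estimated at 6 nM, in the range 1.5 nM to 25 nM.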

Compound 3, inhibition constant: 38.7 nM
Compound 3: middle estimate off by 6.5-fold (0.81 log units), on the low side, outside the stated range (above it).
By their numbers in this assay, from the lowest: compound 2; then compound 1; then compound 3.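

In this assay, among the compounds shown here, the step of a 3.5-fold higher number from compound 1 to compound 3 (0.54 log units; beyond the scatter) is the first single-place comparison, and it shows that this position is sensitive to the exchange. A group of 9 heavy atoms (7 carbon, 2 nitrogen; no ring) in place of a group of 8 heavy atoms (6 carbon, 1 nitrogen, 1 oxygen; no ring) moves the read-out toward weaker inhibition. No available measurement accounts for this step.

This one step cannot separate the contributions of the parts of the exchanged group. As far as these compounds go, how a primary amine or a longer alkyl chain at this position would read remains open.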